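A few compounds are considered here, and "the series" means these few. Any claim that something is new, unique, unknown or untested is made for them only; others in the source may bear on it.

Working notes on the series. Compound 3 `NC(=O)c1c(NC(=O)c2ccccc2Cl)sc2c1CCN(C(=S)Nc1ccccc1F)C2` gives 4970 nM in a functional assay on HL-60 cells (Homo sapiens) for antiproliferative activity, with a stated time of 24 h; a lower number here means a stronger inhibitor, a higher number a weaker inhibitor; it is the second highest of the three numbers measured. Compound 2 `NC(=O)c1c(NC(=O)c2ccccc2Cl)sc2c1CCN(Cc1c(Cl)cccc1Cl)C2` gives 4850 nM, and a 1.0-fold higher number from compound 2 to compound 3 (0.01 log units; within the scatter). Compound 1 `N#Cc1ccccc1CN1CCc2c(sc(NC(=O)c3ccccc3Cl)c2C(N)=O)C1` gives 10400 nM, with a 2.1-fold lower number from compound 1 to compound 3 (0.32 log units; beyond the scatter) and a 2.1-fold lower number from compound 1 to compound 2 (0.33 log units; beyond the scatter). Compound 4 `NC(=O)c1c(NC(=O)c2ccccc2Cl)sc2c1CCN(C(=S)Nc1ccccc1-c1ccccc1)C2` carries phenyl in place of fluoro on an aromatic carbon. For the measured compounds named here, no measured step changes this part of the molecule; the three steps on record all replace the whole group on the ring amine nitrogen, and even those reach only modest size. A step in this assay of comparable or smaller size is therefore expected, without a clear direction, so compound 4 is estimated at 4000 nM (range 1500 nM to 12000 nM), that is a 1.2-fold lower number from compound 3 to compound 4 (0.09 log units; within the scatter).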

Compound 4, half-maximal inhibitory concentration: 34400 nM
Beside the measured number, compound 4's estimate is 8.6-fold (0.93 log units) below it; measured number above the stated range.
By their numbers in this assay, from the lowest: compounds 2 and 3 (each within the scatter of the next); then compound 1; then compound 4.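

In this assay, phenyl in place of fluoro on an aromatic carbon, ortho to a large group, gives a 6.9-fold higher number from compound 3 to compound 4 (0.84 log units; beyond the scatter) and so weakens the compound. This position therefore responds clearly, and this single-group change moves the number further than the replacements of the whole group on the ring amine nitrogen, such as a 2.1-fold lower number from compound 1 to compound 3 (0.32 log units; beyond the scatter). No evidence on record accounts for this step.

On these data alone, whether methyl or chloro at this place stays near compound 3 or moves towards compound 4 remains open. So does the effect of a methoxy group or a pyridyl ring there.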